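The source may report more compounds than this note shows. Statements on the series, on what has been measured and on what is new or still open speak of the compounds shown alone.

Compound 3 `COc1cc2[nH]ncc2cc1-c1ccccc1C(F)(F)F` has the lowest number of the three measured compounds in an assay on CHO-TREX cells for antagonist activity at transient receptor potential cation channel subfamily A member 1 (Homo sapiens), read by FLIPR and calcium flux, with a stated time of 10 min (a lower number here means a stronger inhibitor, a higher number a weaker inhibitor), where compound 3 gives 26 nM. Compound 2 `FC(F)(F)c1ccccc1-c1cc2cn[nH]c2cc1C1CC1` gives 61 nM, and compound 1 `FC(F)(F)c1ccccc1-c1ccc2[nH]ncc2c1` gives 164 nM in this assay. The measured steps are a 2.7-fold lower number from compound 1 to compound 2 (0.43 log units; beyond the scatter), a 6.3-fold lower number from compound 1 to compound 3 (0.80 log units; beyond the scatter) and a 2.3-fold lower number from compound 2 to compound 3 (0.37 log units; beyond the scatter), all modest. Compound 4 `FC(F)(F)Oc1cc2[nH]ncc2cc1-c1ccccc1C(F)(F)F` arises from compound 3 by trifluoromethyl in place of methyl on an oxygen on an aromatic ring. Going by the values given here, none of the measured steps alters what sits on that oxygen; they show only that a methoxy on the aromatic carbon gives the lowest number so far. A step of uncertain direction, probably small, is therefore expected in this assay, a 1.3-fold higher number from compound 3 to compound 4 (0.13 log units; within the scatter). Compound 4 is estimated at 35 nM, within a range from 12 nM to 100 nM.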

Compound 4, half-maximal inhibitory concentration: 36 nM
The estimate for compound 4 lay 1.0-fold (0.01 log units) below the measured number, within the range that was stated.
By their numbers in this assay, from the lowest: compounds 3, 4 and 2 (each within the scatter of the next, the first and the last beyond it); then compound 1.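

Replacing the methyl on the oxygen with trifluoromethyl, a swap of hydrogens for fluorines, leaves the result in this assay within the usual scatter, with a 1.4-fold higher number from compound 3 to compound 4 (0.14 log units; within the scatter). The trifluoromethoxy and cyclopropyl groups also cannot be told apart at their aromatic carbon, with a 1.7-fold lower number from compound 2 to compound 4 (0.23 log units; within the scatter), yet trifluoromethoxy remains clearly better than hydrogen, with a 4.6-fold lower number from compound 1 to compound 4 (0.66 log units; beyond the scatter). No available measurement explains why these fluorines change so little. Still open, on these data alone, is whether a longer chain on that oxygen, such as ethoxy, or an amine on the same aromatic carbon would give a similar number.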